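The compounds below may be only part of what the source reports. "The series", "measured", "known", "first", "only" and "open" are said of these compounds alone.

In a functional assay on HOS-TE85 cells (Homo sapiens) for inhibition, read by CCK-8 assay, with a stated time of 72 h (on this read-out higher numbers stand for weaker inhibition and lower numbers for stronger inhibition), compound 3 `O=C(NCCCCc1ccccc1)c1cccc(C2SCC(=O)N2c2ccc(-c3ccccc3)cc2)c1` gives > 1000 nM, which is a limit and not a number. Compound 1 `CC(C)(C)c1conc1N1C(=O)CSC1c1cccc(C(=O)NCCCCc2ccccc2)c1` gives > 1000 nM, also a limit, and together they make up (the limit of > 1000 nM in this assay, at which 2 of the 3 values shown sit). Compound 2 `Cc1cccc(N2C(=O)CSC2c2cccc(C(=O)NCCCCc3ccccc3)c2)c1` gives a true number, 93.2 nM. Compound 4 `C#Cc1cccc(N2C(=O)CSC2c2cccc(C(=O)NCCCCc3ccccc3)c2)c1` differs from compound 3 as follows: 3-ethynylphenyl in place of 4-phenylphenyl on an amide-type nitrogen in a ring. The closest evidence is an at least 10-fold higher number from compound 2 to compound 3 (1.03 log units; beyond the scatter), a large step beyond the scatter, with 4-phenylphenyl in place of 3-methylphenyl. The step of an at least 10-fold lower number from compound 1 to compound 2 (1.03 log units; beyond the scatter) is also large and favours the 3-methylphenyl of compound 2. With 3-ethynylphenyl entering, a large fall is expected, an at least 6.6-fold lower number from compound 3 to compound 4 (0.82 log units; beyond the scatter). For compound 4 the estimated value is 150 nM, with an expected range of 40 nM to 600 nM.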

Compound 4, half-maximal inhibitory concentration: 149 nM
The estimate for compound 4 lay 1.0-fold (0.00 log units) above the measured number, within the range that was stated.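

Ethynyl in place of methyl on an aromatic carbon gives a 1.6-fold higher number from compound 2 to compound 4 (0.20 log units; within the scatter) in this assay, so on the amide-type nitrogen 3-ethynylphenyl serves as well as 3-methylphenyl. 3-Ethynylphenyl also separates from both other groups, with an at least 6.7-fold lower number from compound 3 to compound 4 (0.82 log units; beyond the scatter) and an at least 6.7-fold lower number from compound 1 to compound 4 (0.82 log units; beyond the scatter), so a second group with one six-membered aromatic ring of carbon only keeps the number low. Both of those steps are lower bounds set by a limit: the limit of > 1000 nM in this assay, at which 2 of the 4 values shown sit.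

The compounds shown leave open how plain phenyl, chlorophenyl or aminophenyl would read on this nitrogen. They also leave open whether a pyridyl ring could replace the carbon-only ring.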